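A few compounds are considered here, and "the series" means these few. Any claim that something is new, unique, unknown or untested is made for them only; others in the source may bear on it.

Measured so far:
compound 1 `CC1(C)Cc2c(sc(NC(=O)c3ccccc3O)c2C(N)=O)C(C)(C)O1` — 4 nM
compound 2 `CC1(C)Cc2c(sc(NC(=O)C(C)(C)O)c2C(N)=O)C(C)(C)O1` — 16 nM

Both were tested in an assay on cells for positive allosteric modulation of Cystic fibrosis transmembrane conductance regulator variant F508del (Homo sapiens), with stated times of 10 min and 7 s, in the presence of a further agent that is not named here; on this read-out lower numbers stand for an effect already at smaller amounts and higher numbers for an effect only at larger amounts of compound. Of the two numbers, compound 2 has the higher one; its nearest neighbour is compound 1, and the step of a 4.0-fold higher number from compound 1 to compound 2 (0.60 log units; beyond the scatter) separates them, so compound 2 needs more material than compound 1 for the same effect. Compound 3 `CC1(C)Cc2c(sc(NC(=O)c3[nH]ncc3Cl)c2C(N)=O)C(C)(C)O1` has not been measured. It differs from compound 2 in one place: a group of 6 heavy atoms (3 carbon, 2 nitrogen, 1 chlorine; one five-membered aromatic ring with 2 hetero atoms) in place of a group of 4 heavy atoms (3 carbon, 1 oxygen; no ring), on a carbonyl carbon. Going by the values given here, only one measured step bears on this change: a 4.0-fold higher number from compound 1 to compound 2 (0.60 log units; beyond the scatter) shows that replacing 2-hydroxyphenyl with 1-hydroxy-1-methylethyl on that carbonyl carbon raised the number modestly. Compound 3 returns an aromatic ring to that position, though a different one from the ring in compound 1. For compound 3 a modest fall is therefore expected, a 2.7-fold lower number from compound 2 to compound 3 (0.43 log units; beyond the scatter). Compound 3 is estimated at 6 nM, within a range from 2 nM to 25 nM.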

Compound 3, half-maximal effective concentration: 2 nM
The estimate for compound 3 lay 3.0-fold (0.48 log units) above the measured number; measured number inside the range.
By their numbers in this assay, from the lowest: compounds 3 and 1 (each within the scatter of the next); then compound 2.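

The step of an 8.0-fold lower number from compound 2 to compound 3 (0.90 log units; beyond the scatter) shows that this position on the carbonyl carbon takes a chlorine-bearing five-membered aromatic ring with 2 hetero atoms in place of the open-chain 1-hydroxy-1-methylethyl, and that the change matters more than the earlier step suggested. The step of a 2.0-fold lower number from compound 1 to compound 3 (0.30 log units; within the scatter) lies within the usual scatter, so this ring and the 2-hydroxyphenyl of compound 1 cannot be told apart on this read-out, and an aromatic ring here need not be six-membered and made of carbon only. No measurement available here explains how the ring change acts on the number.

Still open, as far as these compounds go, is what the chlorine contributes on its own, compared with the same ring carrying hydrogen in its place. Also open, from the compounds shown here alone, is how an amine or a longer carbon chain on this carbonyl carbon would compare.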